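The compounds below may be only part of what the source reports. "The series", "measured", "known", "first", "only" and "open" are said of these compounds alone.

In an ADME assay on WI-38 cells (Homo sapiens) for cytotoxicity, read by MTT assay, with a stated time of 72 h (on this read-out lower numbers stand for stronger inhibition and higher numbers for weaker inhibition), compound 1 `CC(C)c1cccc(NC(=O)CCc2cccc3c2B(O)OC3)c1` gives 22000 nM. Among the measured compounds shown here, compound 2 `COc1cc(OC)cc(-c2cccc(NC(=O)CCc3cccc4c3B(O)OC4)c2)c1` gives 1700 nM, the lowest of the two numbers so far. Compound 3 `COc1cc(OC)cc(-c2cccc(NC(=O)CCc3ccc4c(c3)B(O)OC4)c2)c1` has the same atoms as compound 2, joined differently: a group of 10 heavy atoms (7 carbon, 1 boron, 2 oxygen; one five-membered non-aromatic ring with 2 hetero atoms, one six-membered aromatic ring of carbon only) in place of a group of 10 heavy atoms (7 carbon, 1 boron, 2 oxygen; one five-membered non-aromatic ring with 2 hetero atoms, one six-membered aromatic ring of carbon only), on a saturated chain carbon, two bonds along the chain from a carbonyl carbon. For the measured compounds named here, the only measured step, a 13-fold lower number from compound 1 to compound 2 (1.11 log units; beyond the scatter), lies in another part of the molecule and does not size this change. Going by these compounds, no shift beyond the scatter is therefore expected, and the direction stays open. The estimated step is a 1.3-fold higher number from compound 2 to compound 3 (0.11 log units; within the scatter). For compound 3 the expected value is 2200 nM, with an estimated range of 700 nM to 7000 nM.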

Compound 3, half-maximal inhibitory concentration: > 100000 nM
Compound 3: a limit, no number; the forecaster's own chance of this, stated with the estimate: 3%; at least 45-fold (1.65 log units) between middle value and limit.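

In this assay, exchanging two groups with the same atoms and rings, on a saturated chain carbon, two bonds along the chain from a carbonyl carbon, gives an at least 58-fold higher number from compound 2 to compound 3 (1.76 log units; beyond the scatter). This place therefore responds to how the atoms are joined, not only to which atoms are present, a sensitivity that the change in another part of the molecule could not show. Compound 3 carries a limit, not a number, so the true size of the step stays unknown: the limit of > 100000 nM in this assay, at which 1 of the 3 values shown sits.

Going by these compounds, whether the same rearrangement has a similar effect with isopropyl in place of 3,5-dimethoxyphenyl remains open. Also open, on these data alone, is how a longer chain or an amine at this place would read out.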